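Chloro added to a fluorobenzyl side chain

A few compounds are considered here, and "the series" means these few. Any claim that something is new, unique, unknown or untested is made for them only; others in the source may bear on it.

compound 1 `OC[C@H]1O[C@@H](n2cnc3c(NCc4ccc(F)cc4)ncnc32)[C@H](O)[C@@H]1O` — "not determined" (no result reported)
compound 2 `OC[C@H]1O[C@@H](n2cnc3c(NCc4ccc(Cl)cc4)ncnc32)[C@H](O)[C@@H]1O` — > 166000 nM
compound 3 `OC[C@H]1O[C@@H](n2cnc3c(NCc4ccc(Cl)c(Cl)c4)ncnc32)[C@H](O)[C@@H]1O` — > 166000 nM

In a functional assay on B16 cells (Mus musculus) for antiproliferative activity, with a stated time of 72 h (on this read-out lower numbers stand for stronger inhibition and higher numbers for weaker inhibition), compound 1 gives "not determined" (no result reported), so it stands nowhere on the numbers. The two further values shown are limits. Compound 2 gives only a limit, > 166000 nM. Compound 3 likewise gives only a limit, > 166000 nM. The step that the two limits leave unreadable from compound 2 to compound 3 cannot be sized because both ends sit at the limit of > 166000 nM in this assay, at which 2 of the 3 values shown sit. Compound 4 `OC[C@H]1O[C@@H](n2cnc3c(NCc4ccc(F)c(Cl)c4)ncnc32)[C@H](O)[C@@H]1O` differs from compound 1 by chloro in place of hydrogen on an aromatic carbon, the same kind of change as that between compound 2 and compound 3. Among the compounds with values here, no measured step reads on it; what bears on it is only that both chlorinated neighbours sit at the limit of > 166000 nM in this assay, at which 2 of the 3 values shown sit, so no step beyond the scatter can be read in either direction. Compound 4 is expected to fall near 200000 nM, within 50000 nM to 1000000 nM, most likely again reported only as a limit.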

Compound 4, half-maximal inhibitory concentration: 167000 nM
For compound 4 the middle estimate is 1.2-fold (0.08 log units) above the measured one, within the range that was stated.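

No step can be read from compound 2 or compound 3 to compound 4, because compound 2 and compound 3 give only limits: the limit of > 166000 nM in this assay, at which 2 of the 4 values shown sit.
Still open, on these data alone, is whether any change on the benzyl side chain gives a readable shift in this assay at all.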